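Fluoro on the Anilide Ring of a Pyrrolopyrimidine Isothiocyanate

The source may hold more compounds than are shown below. What is called first, only, known or untested is meant among the compounds shown, and "the series" means these compounds.

Measured compounds:
compound 1 `CN(C)C(=O)c1cc2cnc(Nc3ccc(S(=O)(=O)NCCCCN=C=S)cc3)nc2n1C1CCCC1` — 29.9%
compound 2 `CN(C)C(=O)c1cc2cnc(Nc3ccc(C(=O)NCCCN=C=S)cc3)nc2n1C1CCCC1` — 65.1%
compound 3 `CN(C)C(=O)c1cc2cnc(Nc3ccc(C(=O)NCCCCCCN=C=S)cc3)nc2n1C1CCCC1` — 49.4%

Three compounds share one core and differ only in the side chain on the aromatic ring. In a functional assay on NCI-H1299 cells (Homo sapiens) for inhibition, read by CCK-8 assay, with a stated time of 72 h, tested at 1 uM (a lower number here means a weaker effect, a higher number a stronger effect of the compound at the concentration tested), compound 2 stands highest of the three; compound 3 comes nearest, and compound 1 lies furthest. The step of a number 35.2 percentage points higher from compound 1 to compound 2 (beyond the scatter) and the step of a number 19.5 percentage points higher from compound 1 to compound 3 (beyond the scatter) both run upward from compound 1, while the step of a number 15.7 percentage points lower from compound 2 to compound 3 (beyond the scatter) runs downward as the chain grows longer.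

Compound 4 `CN(C)C(=O)c1cc2cnc(Nc3ccc(C(=O)NCCCN=C=S)cc3F)nc2n1C1CCCC1` keeps the whole side chain of compound 2 and alters the ring instead: fluoro in place of hydrogen on an aromatic carbon. For the measured compounds named here, none of the measured steps touches this ring position; all three concern the chain on the aromatic carbon or its length. Going by the values given here, there is therefore no measured step that bears directly on the change from compound 2 to compound 4. Among the compounds with values here, with no guiding step, the expected change in this assay is none beyond the scatter, in either direction, with a somewhat wider range to admit the unknown. For compound 4 the estimated value is 60%, between 40% and 80%. This expectation amounts to the step of a number 5.1 percentage points lower from compound 2 to compound 4 (within the scatter).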

Compound 4, a percentage reported as inhibition, at one concentration (the size of the read-out at that concentration, not a potency): 9.27%
Beside the measured number, compound 4's estimate is 50.7 percentage points above it, outside the stated range (below it).
By their numbers in this assay, from the lowest: compound 4; then compound 1; then compound 3; then compound 2.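

The earlier compounds shown here varied only the side chain and its length, so they said nothing about the aromatic ring that carries it. Here the ring itself proves sensitive: with the side chain of compound 2 kept whole, fluoro in place of hydrogen, on an aromatic carbon ortho to a large group, gives in this assay the step of a number 55.8 percentage points lower from compound 2 to compound 4 (beyond the scatter), larger than any step among the chain variants, although only one fluorine atom enters. Nothing available explains why this single atom has so large an effect on the read-out.

The compounds shown leave open whether the loss belongs to fluoro in particular or would also follow from another small group at this carbon, such as chloro, methyl or methoxy, or from fluoro on another carbon of the same ring. They also leave open whether fluoro would have a similar effect alongside the longer chain of compound 3 or the sulfonamide link of compound 1, since its effect is seen for one side chain only.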